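The compounds below may be only part of what the source reports. "The series", "measured", "known", "first", "only" and "open" are said of these compounds alone.

Of the compounds shown here, two with a shared core have been measured in an assay on isolated protein for agonist activity at Glucose-dependent insulinotropic receptor (Homo sapiens); on this read-out lower numbers stand for an effect already at smaller amounts and higher numbers for an effect only at larger amounts of compound. Compound 1 `CC(C)(C)OC(=O)N1CCC(O[C@H]2CC[C@H](Oc3ccc(S(C)(=O)=O)cc3F)CC2)CC1` carries a methylsulfonyl group on a fluorinated phenyl ring at the ether oxygen, and in this assay compound 1 gives 227 nM. Compound 2 `CC(C)(C)OC(=O)N1CCC(O[C@H]2CC[C@H](Oc3ccc(C#N)cc3)CC2)CC1` carries a 4-cyanophenyl group at the same oxygen, and in this assay compound 2 gives 334 nM. The two numbers lie within the scatter of each other, so nothing separates compound 1 from compound 2 on this read-out.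

Compound 3 `CC(C)(C)OC(=O)N1CCC(O[C@H]2CC[C@H](Oc3cnc(S(C)(=O)=O)cn3)CC2)CC1` has not yet been measured. Relative to compound 2 the change is 5-(methylsulfonyl)pyrazin-2-yl in place of 4-cyanophenyl on an oxygen on a saturated carbon. Among the compounds with values here, no measured pair shows the size of this particular step. The methylsulfonyl group, however, is already present in compound 1 on an all-carbon ring, where it gives 227 nM, a number within the scatter of compound 2. Within the data shown here, on that basis compound 3 is expected to land close to the two known numbers, with the step of a 1.3-fold lower number from compound 2 to compound 3 (0.11 log units; within the scatter) expected to stay within the scatter or near it. The estimate for compound 3 in this assay is 260 nM, with a range from 80 nM to 850 nM.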

Compound 3, half-maximal effective concentration: 94 nM
Compound 3: the middle estimate sits 2.8-fold (0.44 log units) above what was measured; measured number inside the range.
By their numbers in this assay, from the lowest: compound 3; then compounds 1 and 2 (each within the scatter of the next).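

In this assay, within the data shown here, the step of a 3.6-fold lower number from compound 2 to compound 3 (0.55 log units; beyond the scatter) is the first change of the group on an oxygen on a saturated carbon that reaches beyond the scatter, so this position can respond to the group placed there, which compounds 1 and 2 alone could not show. The swap changes two things at once, a ring with 2 hetero atoms replacing a ring of carbon only and methylsulfonyl replacing the nitrile, and the step does not say which of the two matters; compound 1, with methylsulfonyl on a fluorinated phenyl ring, gives 227 nM, while compound 3 gives 94 nM. No measurement here bears on why the number changes at this step.

Open, on these data alone, is how 5-(methylsulfonyl)pyrazin-2-yl would compare with the same ring carrying another group, such as an amine or a carboxylic acid, in place of methylsulfonyl. As far as these compounds go, all three compounds also share the rest of their core unchanged, so whether this step would keep its size on a different core remains unknown.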